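Compound 4: will the 3-fluorophenyl result hold?

This account rests on a few compounds, and the source may have more. Where it says the series, first, only, none or still open, it means among the compounds named here.

Compound 1 `COc1ccc(-c2cccc3c2N(S(=O)(=O)c2ccc(OC)cc2)CC3)cc1` gives 352 nM
Compound 2 `COc1ccc(S(=O)(=O)N2CCc3cccc(-c4ccncc4)c32)cc1` gives 106 nM
Compound 3 `COc1ccc(S(=O)(=O)N2CCc3cccc(-c4cccc(F)c4)c32)cc1` gives 92.4 nM

All three values come from a functional assay on KB-VIN10 cells (Homo sapiens) for inhibition, with a stated time of 72 h; a lower number here means a stronger inhibitor, a higher number a weaker inhibitor. Compound 3 shares the low end of this small set with its nearest neighbour, the gap being a 1.1-fold lower number from compound 2 to compound 3 (0.06 log units; within the scatter). The set's largest gap is a 3.8-fold lower number from compound 1 to compound 3 (0.58 log units; beyond the scatter).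

Compound 4 `COc1ccc(S(=O)(=O)N2CCc3cccc(-c4ccc(O)cc4)c32)cc1` carries 4-hydroxyphenyl in place of 3-fluorophenyl on an aromatic carbon. Going by the values given here, no measured compound has a 4-hydroxyphenyl group. The closest measured group is the 4-methoxyphenyl of compound 1, so the step of a 3.8-fold lower number from compound 1 to compound 3 (0.58 log units; beyond the scatter) bears most directly when read in reverse. The step of a 3.3-fold lower number from compound 1 to compound 2 (0.52 log units; beyond the scatter) is of similar size and also starts from that group. A modest move towards a higher number in this assay is therefore expected, without reaching the number that compound 1 gives (352 nM). The expected step is a 2.2-fold higher number from compound 3 to compound 4 (0.34 log units; beyond the scatter). Compound 4 is estimated at 200 nM (range 70 nM to 500 nM).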

Compound 4, half-maximal inhibitory concentration: 123 nM
Compound 4: the middle estimate sits 1.6-fold (0.21 log units) above what was measured, within the range that was stated.
By their numbers in this assay, from the lowest: compounds 3, 2 and 4 (each within the scatter of the next); then compound 1.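

In this assay the hydrogen-bond donor and acceptor that 4-hydroxyphenyl brings in place of 3-fluorophenyl give no separable change (a 1.3-fold higher number from compound 3 to compound 4 (0.12 log units; within the scatter)), and the exchange for pyridin-4-yl reads the same (a 1.2-fold higher number from compound 2 to compound 4 (0.06 log units; within the scatter)). Going by these compounds alone, the new information lies in the single change on the oxygen, hydrogen in place of methyl (a 2.9-fold lower number from compound 1 to compound 4 (0.46 log units; beyond the scatter)), which shows that removing that one methyl from compound 1 is enough to bring the number into the range of compound 2 and compound 3. Nothing measured here gives a reason for this difference.

From the compounds shown here alone, whether an ethoxy group or a longer ether chain on that oxygen behaves like the methyl of compound 1 remains open. Also open, going by these compounds, is whether 3-hydroxyphenyl, or an amine or a carboxylic acid on the same phenyl ring, stays level with compound 4.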